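This account rests on a few compounds, and the source may have more. Where it says the series, first, only, none or still open, it means among the compounds named here.

In a functional assay on cells (Platelet, Homo sapiens) for inhibition (on this read-out higher numbers stand for weaker inhibition and lower numbers for stronger inhibition), compound 1 `CCOC(=O)c1ccc(-c2nn(Cc3ccc(Cl)cc3)c3ccccc23)cc1` gives 120 nM and compound 2 `CCOC(=O)c1ccc(-c2nn(Cc3ccccc3OC)c3ccccc23)cc1` gives 470 nM, so compound 2 holds the higher of the two numbers. Compound 3 `CCOC(=O)c1cccc(-c2nn(Cc3ccccc3)c3ccccc23)c1` reads > 10000 nM, which is a limit of the assay. Compound 4 `CCOC(=O)c1ccc(-c2nn(Cc3ccncc3)c3ccccc23)cc1` carries pyridin-4-yl in place of 2-methoxyphenyl on a saturated chain carbon bound to an aromatic nitrogen. Within the data shown here, one measured step touches this place, a 3.9-fold higher number from compound 1 to compound 2 (0.59 log units; beyond the scatter), and it is modest. Among the measured compounds shown here, no pyridin-4-yl compound has yet been measured, so that step is only a rough guide. A weakening of similar size is expected, namely a 3.2-fold higher number from compound 2 to compound 4 (0.50 log units; beyond the scatter). For compound 4 the estimated value in this assay is 1500 nM, with an expected range from 300 nM to 8000 nM.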

Compound 4, half-maximal inhibitory concentration: 5630 nM
Beside the measured number, compound 4's estimate is 3.8-fold (0.57 log units) below it; measured number inside the range.
By their numbers in this assay, from the lowest: compound 1; then compound 2; then compound 4. At a limit, above all of these: compound 3.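

In this assay, pyridin-4-yl brings a large step, a 12-fold higher number from compound 2 to compound 4 (1.08 log units; beyond the scatter), and measured from 4-chlorophenyl the step is a 47-fold higher number from compound 1 to compound 4 (1.67 log units; beyond the scatter). This place is therefore far more sensitive to the group it carries than the modest step between compound 1 and compound 2 alone had indicated, and among these three compounds the one with nitrogen in the ring is the weakest inhibitor. Nothing shown here accounts for the size of this loss. Still open, going by these compounds, is how pyridin-3-yl or cyclohexyl would read at this place, and whether the loss follows the ring nitrogen's location.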